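The source may hold more compounds than are shown below. What is called first, only, known or untested is meant among the compounds shown, and "the series" means these compounds.

Measured so far:
compound 1 `CCCCCOc1cc(CCc2nc(C)c(CC)s2)nc(NCc2cc(Cl)cc(NC(=O)OC(C)C)c2)c1` — 35 nM in an assay on cells for binding affinity to Neuropeptide Y receptor type 1 (Homo sapiens); a lower number here means a stronger inhibitor, a higher number a weaker inhibitor
compound 2 `CCCCCCCOc1cc(CCc2nc(C)c(CC)s2)nc(NCc2cc(Cl)cc(NC(=O)OC(C)C)c2)c1` — 72 nM
compound 3 `CCc1sc(CCc2cc(OC3CCC3)cc(NCc3cc(Cl)cc(NC(=O)OC(C)C)c3)n2)nc1C` — 11 nM

Compound 3 has the lowest number of the three in this assay, with a 3.2-fold lower number from compound 1 to compound 3 (0.50 log units; beyond the scatter) and a 6.5-fold lower number from compound 2 to compound 3 (0.82 log units; beyond the scatter). Both of those steps replace a straight chain on the oxygen on the aromatic ring with the smaller cyclobutyl, and both lower the number.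

Compound 4 `CCc1sc(CCc2cc(OC3CCCCC3)cc(NCc3cc(Cl)cc(NC(=O)OC(C)C)c3)n2)nc1C` is not yet measured. It differs from compound 3 in one place: cyclohexyl in place of cyclobutyl on an oxygen on an aromatic ring. The entering ring is larger than the leaving one. Among the measured steps, the ones that bear on this are the two just named, where a larger group on that oxygen went with a higher number, and a 2.1-fold higher number from compound 1 to compound 2 (0.31 log units; beyond the scatter), where lengthening the chain also raised the number. The expectation is therefore a modest rise, though a ring of this size has not been tested here, so the size of the step is uncertain. Compound 4 is estimated at 22 nM, ranging from 8 nM to 60 nM, which would mean an expected 2.0-fold higher number from compound 3 to compound 4 (0.30 log units; within the scatter).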

Compound 4, half-maximal inhibitory concentration: 29 nM
The estimate for compound 4 lay 1.3-fold (0.12 log units) below the measured number; low and high end bracket the measured number.
By their numbers in this assay, from the lowest: compound 3; then compounds 4 and 1 (each within the scatter of the next); then compound 2.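

In this assay there is a 2.6-fold higher number from compound 3 to compound 4 (0.42 log units; beyond the scatter) when cyclobutyl gives way to cyclohexyl on this oxygen, so the size of the ring matters here, not only the choice of a ring over a straight chain. Against the chains the picture is split, with a 2.5-fold lower number from compound 2 to compound 4 (0.39 log units; beyond the scatter) for cyclohexyl in place of heptyl but a 1.2-fold lower number from compound 1 to compound 4 (0.08 log units; within the scatter) for cyclohexyl in place of pentyl, so a ring on this oxygen does not by itself lower the number. Nothing at hand explains why the numbers shift with the group on this oxygen.

The compounds shown leave open how cyclopentyl, cyclopropyl or a plain methyl would read at this position, and so whether cyclobutyl is the best size. They also leave open what a ring holding an oxygen atom, such as tetrahydropyranyl, would do here.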